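The source may report more compounds than this note shows. Statements on the series, on what has been measured and on what is new or still open speak of the compounds shown alone.

In a functional assay on QG-56 cells (Homo sapiens) for cytotoxicity, read by MTT assay, with a stated time of 48 h (on this read-out lower numbers stand for stronger inhibition and higher numbers for weaker inhibition), compound 1 `COc1cc(/C=C/C(=O)C2=C(/C=C/c3ccc(O)c(OC)c3)NC(=O)NC2c2ccccc2)ccc1O` gives 50000 nM. Compound 2 `COc1cc(/C=C/C(=O)C2=C(/C=C/c3ccc(O)c(OC)c3)NC(=O)NC2c2ccccc2O)ccc1O` gives 100000 nM, and compound 3 `COc1cc(/C=C/C(=O)C2=C(/C=C/c3ccc(O)c(OC)c3)NC(=O)NC2c2ccc(O)cc2)ccc1O` gives 50000 nM. Compound 3 therefore stands level with compound 1, and the gap between compound 3 and compound 2 lies within the scatter. All three differ only in the aromatic group on one saturated ring carbon, and the steps there are small: a 2.0-fold higher number from compound 1 to compound 2 (0.30 log units; within the scatter), no change at the digits printed from compound 1 to compound 3 (within the scatter) and a 2.0-fold lower number from compound 2 to compound 3 (0.30 log units; within the scatter). The next structure, compound 4 `COc1cc(/C=C/C(=O)C2=C(/C=C/c3ccc(O)c(OC)c3)NC(=O)NC2c2c(Cl)cccc2Cl)ccc1O`, changes that same carbon, with 2,6-dichlorophenyl in place of 4-hydroxyphenyl on a saturated ring carbon. Within the data shown here, none of the measured compounds carries chlorine, so the hydroxy steps bear on this change only indirectly. With all three of them inside the scatter, no step beyond the scatter is expected in this assay, and no direction is favoured with any confidence. The estimated outcome is a 1.3-fold lower number from compound 3 to compound 4 (0.10 log units; within the scatter). For compound 4 the expected value is 40000 nM, with an estimated range from 12000 nM to 100000 nM.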

Compound 4, half-maximal inhibitory concentration: 100000 nM
Compound 4: the middle estimate sits 2.5-fold (0.40 log units) below what was measured; low and high end bracket the measured number.
By their numbers in this assay, from the lowest: compounds 1, 3, 2 and 4 (each within the scatter of the next).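

In this assay, the change on this saturated ring carbon gives a 2.0-fold higher number from compound 3 to compound 4 (0.30 log units; within the scatter) when set against 4-hydroxyphenyl, no change at the digits printed from compound 2 to compound 4 (within the scatter) when set against 2-hydroxyphenyl and a 2.0-fold higher number from compound 1 to compound 4 (0.30 log units; within the scatter) when set against phenyl on the same carbon. The earlier compounds shown here tested only hydroxy against hydrogen on the aromatic group, whereas compound 4 shows that 2,6-dichlorophenyl, with neither hydrogen-bond donors nor acceptors, also stays within the scatter of all three. No evidence on the cause of these results is at hand.

As far as these compounds go, whether an amine or a carboxylic acid on this aromatic group, or a longer chain in its place, would move the number beyond the scatter stays open. The compounds shown also leave open how far changes elsewhere on the shared core, such as at the 2-(4-hydroxy-3-methoxyphenyl)ethenyl group, would move it.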